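Swapping Isobutoxy for Trifluoromethyl at an Assay Limit

A few compounds are considered here, and "the series" means these few. Any claim that something is new, unique, unknown or untested is made for them only; others in the source may bear on it.

Measured in an ADME assay on Raji cells (Homo sapiens) for cytotoxicity, read by luminescence, with a stated time of 72 h (a lower number here means that less compound is needed, a higher number that more compound is needed for the effect), with limits only:
Compound 1 `CCOC(=O)c1c(-c2ccccc2)[nH]c2cc(OC)ccc2c1=O` gives > 21500 nM as a limit
Compound 2 `CCOC(=O)c1c(-c2cccc(OCC(C)C)c2)[nH]c2cc(OC)ccc2c1=O` gives > 21500 nM as a limit

Compound 2 stands only at the limit of > 21500 nM in this assay, at which 2 of the 2 values shown sit, and has no number. Compound 3 `CCOC(=O)c1c(-c2cccc(C(F)(F)F)c2)[nH]c2cc(OC)ccc2c1=O` carries trifluoromethyl in place of isobutoxy on an aromatic carbon. For the measured compounds named here, the one measured step bearing on this is a step that the two limits leave unreadable from compound 1 to compound 2 with isobutoxy in place of hydrogen on an aromatic carbon, and it gives no size to carry over, so no step beyond the scatter is expected in this assay in either direction. The expected change is a step that the limit leaves unreadable from compound 2 to compound 3 and may well appear as another limit. For compound 3 the estimate is 22000 nM with an expected range of 9000 nM to 45000 nM if a number is reported.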

Compound 3, half-maximal effective concentration: > 21500 nM
Compound 3: a limit, no number (the forecaster's own chance of this, stated with the estimate: 85%); the middle value does not contradict the limit.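

No step can be read among compound 1, compound 2 and compound 3, because each gives only a limit and no number: the limit of > 21500 nM in this assay, at which 3 of the 3 values shown sit.

These compounds leave open whether hydrogen, isobutoxy and trifluoromethyl differ at all in this assay.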